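This account rests on a few compounds, and the source may have more. Where it says the series, first, only, none or still open, it means among the compounds named here.

Measured so far in an ADME assay (liver) for metabolic stability, with Liver microsome (Rattus norvegicus) as the target, using microsomes; on this read-out lower numbers stand for slow clearance and higher numbers for fast clearance:

- compound 1 `O=C1Cc2cc(-c3nnc(NCc4ccccc4)o3)ccc2N1` gives < 14 mL.min-1.g-1 (a limit)
- compound 2 `c1ccc(CNc2nnc(-c3c[nH]c4ncccc34)o2)cc1` gives 40 mL.min-1.g-1
- compound 3 `Fc1ccccc1CNc1nnc(-c2c[nH]c3ncccc23)o1` gives 46 mL.min-1.g-1

The value of compound 1 is a limit of the assay, not a number. Within the data shown here, its core also differs from the one that compounds 2 and 3 share. Compound 3 stands at 46 mL.min-1.g-1 and compound 2 at 40 mL.min-1.g-1, two values within the scatter of each other.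

The unmeasured compound 4 `Fc1cccc(CNc2nnc(-c3c[nH]c4ncccc34)o2)c1` keeps the core of compound 3 and has the same atoms, joined differently. It has 3-fluorophenyl in place of 2-fluorophenyl on a saturated chain carbon bound to a nitrogen on an aromatic ring. Among the measured compounds shown here, the one measured step that bears on this is fluoro in place of hydrogen on an aromatic carbon, a 1.2-fold higher number from compound 2 to compound 3 (0.06 log units; within the scatter), and it lies within the scatter. For the measured compounds named here, no measured compound carries the 3-fluorophenyl group, and the new placement of the fluoro has therefore not been tested directly.

Going by the values given here, with only that small step to go on, no change beyond the scatter is expected in this assay. The expected size of the step is a 1.0-fold lower number from compound 3 to compound 4 (0.01 log units; within the scatter). For compound 4 the estimate is 45 mL.min-1.g-1, with an expected range from 25 mL.min-1.g-1 to 80 mL.min-1.g-1.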

Compound 4, intrinsic clearance in microsomes: 71 mL.min-1.g-1
For compound 4 the middle estimate is 1.6-fold (0.20 log units) below the measured one, and the stated range covers the measured number.
By their numbers in this assay, from the lowest: compounds 2, 3 and 4 (each within the scatter of the next). At a limit, below all of these: compound 1.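

In this assay, the fluoro has now been read in a second placement on the phenyl ring, and swapping 2-fluorophenyl for 3-fluorophenyl gives a step that stays within the scatter (a 1.5-fold higher number from compound 3 to compound 4 (0.19 log units; within the scatter)), as does putting fluoro in place of hydrogen to reach the 3-fluorophenyl group (a 1.8-fold higher number from compound 2 to compound 4 (0.25 log units; within the scatter)). Neither fluoro placement can therefore be told apart from the other or from the unsubstituted phenyl ring, so compounds 2, 3 and 4 read as one group on this measure of clearance, with no effect of the fluoro's placement shown at this position. Nothing among the data shown accounts for the small differences in the numbers of these three compounds.

Still open, on these data alone, is whether a larger change would separate itself from the scatter, such as an amine or a carboxylic acid on the phenyl ring, or a longer chain in place of the saturated chain carbon. As far as these compounds go, compound 1 gives < 14 mL.min-1.g-1, which is a limit of the assay and not a number, and how a fluoro on its phenyl ring would read on that different core remains unknown.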